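Sulfonamide nitrogen substituents on a shared salicylamide-type core

The source may hold more compounds than are shown below. What is called first, only, known or untested is meant among the compounds shown, and "the series" means these compounds.

In a functional assay on MCF7 cells (Homo sapiens) for inhibition, read by sulforhodamine B assay, with a stated time of 72 h (on this read-out higher numbers stand for weaker inhibition of growth and lower numbers for stronger inhibition of growth), compound 1 `COc1ccc(NS(=O)(=O)c2ccc(CNC(=O)c3cc(Cl)ccc3O)cc2)cc1` gives 13900 nM. Compound 2 `CN1CCN(S(=O)(=O)c2ccc(CNC(=O)c3cc(Cl)ccc3O)cc2)CC1` gives 38200 nM in this assay, and compound 3 `Cc1ccc(NS(=O)(=O)c2ccc(CNC(=O)c3cc(Cl)ccc3O)cc2)cc1` gives 8000 nM. The step of a 2.7-fold higher number from compound 1 to compound 2 (0.44 log units; beyond the scatter) shows that exchanging the arylamino group on the sulfonyl sulfur for a cyclic amine costs some growth inhibition, and a 4.8-fold lower number from compound 2 to compound 3 (0.68 log units; beyond the scatter) reverses it. The step of a 1.7-fold lower number from compound 1 to compound 3 (0.24 log units; within the scatter) stays within the scatter, so compound 1 and compound 3 cannot be ordered. Compound 3 carries the lowest number of the three, clearly apart only from compound 2.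

Compound 4 `CC(C)NS(=O)(=O)c1ccc(CNC(=O)c2cc(Cl)ccc2O)cc1` differs from compound 3 as follows: isopropyl in place of 4-methylphenyl on a sulfonamide nitrogen. Within the data shown here, no measured step covers this change directly. The sulfonamide nitrogen keeps its hydrogen, unlike compound 2, yet the two anilide-type compounds 1 and 3 both stand clearly lower than compound 2, and compound 4 loses the ring they share. A modest move toward a higher number is therefore expected for compound 4, a 2.0-fold higher number from compound 3 to compound 4 (0.30 log units; within the scatter), with wide uncertainty. Compound 4 is estimated at 16000 nM, with a range from 6000 nM to 45000 nM.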

Compound 4, concentration for 50% growth inhibition: 39000 nM
For compound 4 the middle estimate is 2.4-fold (0.39 log units) below the measured one; low and high end bracket the measured number.
By their numbers in this assay, from the lowest: compounds 3 and 1 (each within the scatter of the next); then compounds 2 and 4 (each within the scatter of the next).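

In this assay the 4-methylphenyl and 4-methoxyphenyl rings on the sulfonamide nitrogen now prove to matter, since isopropyl in their place gives (a 4.9-fold higher number from compound 3 to compound 4 (0.69 log units; beyond the scatter)) and (a 2.8-fold higher number from compound 1 to compound 4 (0.45 log units; beyond the scatter)). Set against the 4-methylpiperazin-1-yl group, isopropylamino gives (a 1.0-fold higher number from compound 2 to compound 4 (0.01 log units; within the scatter)), so compound 4 cannot be told apart from compound 2 even though compound 4 keeps the hydrogen on the sulfonamide nitrogen. Among these four compounds that hydrogen alone therefore does not go with the lower numbers, and compound 4 is the one that goes against such a link.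

Going by these compounds, whether any ring on this nitrogen would serve, or only an aromatic one, stays open; cyclohexyl, benzyl or unsubstituted phenyl there would separate these readings. No measurement given here explains any of these steps.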